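A few compounds are considered here, and "the series" means these few. Any claim that something is new, unique, unknown or untested is made for them only; others in the source may bear on it.

Measured compounds:
compound 1, `O=[N+]([O-])c1cc(-c2nnn(Cc3cccc(Cl)c3)n2)cc([N+](=O)[O-])c1`, gives 27000 nM in an ADME assay on CHO-K1 cells (Cricetulus griseus) for cytotoxicity, read by MTT assay, with a stated time of 24 h; a higher number here means a weaker inhibitor, a lower number a stronger inhibitor;
compound 2, `O=[N+]([O-])c1cc(-c2nnn(CSc3nnnn3C3CCCCC3)n2)cc([N+](=O)[O-])c1`, gives 140000 nM in this assay.

Compound 2 stands at the highest of the two numbers in this assay. Within the data shown here, its only neighbour, compound 1, gives a clearly lower number, and that gap lies beyond the usual scatter of this kind of measurement, so compound 2 is the weaker of the two.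

The step from compound 2 leads to compound 3, `O=[N+]([O-])c1cc(-c2nnn(CSc3nnnn3-c3ccc(Br)cc3)n2)cc([N+](=O)[O-])c1`, which is not yet measured. The change is 4-bromophenyl in place of cyclohexyl on an aromatic nitrogen. Among the measured compounds shown here, no measured pair shows what such a change does in this assay, so the direction of the step cannot be read from the numbers at hand. The expectation is therefore a step of a 1.4-fold lower number from compound 2 to compound 3 (0.15 log units; within the scatter), which is no step beyond the scatter in either direction. For compound 3 the estimated value in this assay is 100000 nM, with a range from 30000 nM to 300000 nM.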

Compound 3, half-maximal inhibitory concentration: 29000 nM
For compound 3 the middle estimate is 3.4-fold (0.54 log units) above the measured one, and the stated range ends above it.
By their numbers in this assay, from the lowest: compounds 1 and 3 (each within the scatter of the next); then compound 2.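

In this assay the group on the aromatic nitrogen of the five-membered aromatic ring with 4 nitrogen proves able to move the number: 4-bromophenyl in place of cyclohexyl gives a 4.8-fold lower number from compound 2 to compound 3 (0.68 log units; beyond the scatter) and this step, though modest, lies beyond the scatter. Among these compounds, compound 2 and compound 3 form the first measured pair that differs in one place, so this position is now seen to respond to the group it carries, with the aromatic ring bearing bromine on the side of the lower number and the non-aromatic carbon ring on the side of the higher. Nothing at hand accounts for the direction or size of this step.

The compounds shown leave open how much of the step belongs to the aromatic ring and how much to the bromine, a question that plain phenyl, or chlorine in place of the bromine, would address at this position. Also open, going by these compounds, is what a small group such as methyl, or a chain ending in an amine or a carboxylic acid, would give on the same nitrogen.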